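The Same Ether Swap, Measured Once and Expected Again

A few compounds are considered here, and "the series" means these few. Any claim that something is new, unique, unknown or untested is made for them only; others in the source may bear on it.

Measured so far:
compound 1, `COCOc1cccc(C[C@H]2C(=O)OC[C@@H]2Cc2ccccc2)c1`, 80000 nM
compound 2, `CCCCOc1cccc(C[C@H]2C(=O)OC[C@@H]2Cc2ccccc2)c1`, 26000 nM
compound 3, `COCOc1ccc(C[C@H]2C(=O)OC[C@@H]2Cc2ccccc2)cc1`, 71000 nM

All three were tested in a functional assay on HL-60 cells (Homo sapiens) for cytotoxicity, read by WST assay, with a stated time of 48 h; on this read-out lower numbers stand for an effect already at smaller amounts and higher numbers for an effect only at larger amounts of compound. Compound 1 and compound 2 share a core and differ by one change: propyl in place of methoxy on a saturated chain carbon bound to an oxygen on an aromatic ring. That change gave a 3.1-fold lower number from compound 1 to compound 2 (0.49 log units; beyond the scatter). Compound 3 is built from the same atoms as compound 1, joined differently; the difference between the two cores is not broken down here. In this assay compound 3 gives 71000 nM, close to compound 1 within the scatter, while compound 2 stands apart from it.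

Compound 4, `CCCCOc1ccc(C[C@H]2C(=O)OC[C@@H]2Cc2ccccc2)cc1`, has not yet been measured in this assay. It differs from compound 3 by propyl in place of methoxy on a saturated chain carbon bound to an oxygen on an aromatic ring, the same change as from compound 1 to compound 2, made on the core of compound 3. Because the change from compound 1 to compound 2 gave a 3.1-fold lower number from compound 1 to compound 2 (0.49 log units; beyond the scatter), a step of similar size is expected here: the estimated step is a 3.1-fold lower number from compound 3 to compound 4 (0.49 log units; beyond the scatter). This rests on a single measured example, so the expectation is loose. For compound 4 the estimate in this assay is 23000 nM, with a range from 9000 nM to 60000 nM.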

Compound 4, half-maximal effective concentration: 23000 nM
Compound 4: the middle estimate sits on the measured number at the digits printed, and the stated range covers the measured number.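

In this assay, putting propyl in place of methoxy on a saturated chain carbon bound to an oxygen on an aromatic ring, which turns methoxymethoxy into butoxy, gave a 3.1-fold lower number from compound 3 to compound 4 (0.49 log units; beyond the scatter). Set beside the earlier step, the change carried over from one core to the other with no difference beyond the scatter: the same change on two cores in this assay, a 3.1-fold lower number (0.49 log units; beyond the scatter) from compound 1 to compound 2 and a 3.1-fold lower number (0.49 log units; beyond the scatter) from compound 3 to compound 4, 1.0-fold (0.00 log units) apart, within the scatter of two such steps This shows that the step held on these two cores, but two examples cannot show that it would hold on any further core, and they do not explain why the number falls.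

The compounds shown carry only methoxymethoxy or butoxy, so it remains open whether a longer chain such as hexyloxy, or a chain ending in an amine or a carboxylic acid, would shift the number in the same direction. As far as these compounds go, it also remains open whether the same step would appear in any other type of cell.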